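Swapping a Pentyl Chain for a Chlorobenzyl Group

The source may report more compounds than this note shows. Statements on the series, on what has been measured and on what is new or still open speak of the compounds shown alone.

Of the compounds shown here, two sharing one core have been measured in an assay on HEK293 cells for displacement of a labelled ligand from prostaglandin D2 receptor 2 (Homo sapiens); on this read-out lower numbers stand for stronger inhibition and higher numbers for weaker inhibition. Compound 1, `CCCCCCSc1nc2ccccc2n1CC(=O)O`, gives 1360 nM. Compound 2, `CCCCCSc1nc2ccccc2n1CC(=O)O`, gives 1240 nM. Among the compounds with values here, the only step measured so far, a 1.1-fold lower number from compound 1 to compound 2 (0.04 log units; within the scatter), shows that trimming the chain by one carbon left the read-out essentially unchanged. Compound 2 therefore stands at the lower of the two numbers, but its gap to compound 1 falls within the scatter, so nothing separates them.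

The next compound, compound 3, is `O=C(O)Cn1c(SCc2ccc(Cl)cc2)nc2ccccc21`. Its change from compound 2 is 4-chlorophenyl in place of butyl on a saturated chain carbon bound to a sulfur. Within the data shown here, no measured step bears on this change: the one step available, from compound 1 to compound 2, alters only chain length, whereas here a flexible chain gives way to a ring carrying chlorine. The expectation must rest on the observation that chain length made no difference, so the number for compound 3 is estimated with wide uncertainty, and the expected step from compound 2 is a 3.1-fold lower number from compound 2 to compound 3 (0.49 log units; beyond the scatter). Compound 3 is expected to give 400 nM, within the range 80 nM to 2000 nM.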

Compound 3, half-maximal inhibitory concentration: 160 nM
Compound 3: the middle estimate sits 2.5-fold (0.40 log units) above what was measured; the measured number falls inside the stated range.
By their numbers in this assay, from the lowest: compound 3; then compounds 2 and 1 (each within the scatter of the next).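

Shortening the chain had moved nothing, but putting a ring on the saturated chain carbon bound to the sulfur clearly shifts the read-out in this assay: the change to 4-chlorophenyl gives a 7.8-fold lower number from compound 2 to compound 3 (0.89 log units; beyond the scatter), and measured against the pentyl compound the same kind of swap gives an 8.5-fold lower number from compound 1 to compound 3 (0.93 log units; beyond the scatter). This position is therefore not indifferent to what it carries: the two plain chains stay within the scatter of each other, while both steps to the chlorine-bearing ring lie beyond it. No evidence is available on why this swap lowers the number.

The compounds shown do not separate the contribution of the aromatic ring from that of its chlorine, and a plain phenyl group, a 4-fluorophenyl group or a 4-methoxyphenyl group at the same place would help to pull the two apart. From the compounds shown here alone, it also remains open whether a ring of another kind, such as a pyridine or a cyclohexyl group, would give a similar step, and whether the carboxylic acid could give way to a tetrazole.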